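The source may hold more compounds than are shown below. What is called first, only, known or untested is meant among the compounds shown, and "the series" means these compounds.

Working notes. Within the data shown here, in an ADME assay on a cell-free system (plasma, Homo sapiens) for metabolic stability (a lower number here means that the compound disappears faster, a higher number that the compound lasts longer), compound 2 `CCOC(=O)c1ccc(/N=N/N(C)C(=O)OCOC(C)=O)cc1` gives 0.2 h; its only neighbour, compound 1 `CC(=O)OCOC(=O)N(C)/N=N/c1ccc(Br)cc1`, gives 0.283 h, and the step of a 1.4-fold lower number from compound 1 to compound 2 (0.15 log units; within the scatter) lies within the scatter, so the two cannot be told apart in this assay. Compound 3 `CC(=O)OCOC(=O)N(C)/N=N/c1ccc(C)cc1` differs from compound 2 by methyl in place of ethoxycarbonyl on an aromatic carbon. Among the measured compounds shown here, the one measured step at this place, a 1.4-fold lower number from compound 1 to compound 2 (0.15 log units; within the scatter), concerns another exchange and stays within the scatter, so for compound 3 no move beyond the scatter is expected in this assay. Compound 3 is expected to give 0.25 h, within 0.12 h to 0.5 h, meaning a step of a 1.3-fold higher number from compound 2 to compound 3 (0.10 log units; within the scatter).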

Compound 3, half-life: 0.25 h
Estimate against measurement, compound 3: no gap at the digits printed; the measured number falls inside the stated range.
By their numbers in this assay, from the lowest: compounds 2, 3 and 1 (each within the scatter of the next).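

In this assay, methyl is a third group at this aromatic carbon, para to a large group, and the steps stay within the scatter: a 1.3-fold higher number from compound 2 to compound 3 (0.10 log units; within the scatter) and a 1.1-fold lower number from compound 1 to compound 3 (0.05 log units; within the scatter). Exchanging ethoxycarbonyl or bromo for methyl therefore gives no readable change in half-life, so these three groups cannot be told apart here. No supporting data bear on this result. From the compounds shown here alone, whether an amine or a carboxylic acid at this place would move the half-life beyond the scatter remains open. Also open, going by these compounds, is how changes elsewhere on the shared core would read.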